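This account rests on a few compounds, and the source may have more. Where it says the series, first, only, none or still open, it means among the compounds named here.

The three measured compounds in a functional assay on 1321-N1 cells for agonist activity at P2Y purinoceptor 2 (Homo sapiens), read by scintillation counting and inositol phosphate accumulation; a higher number here means that more compound is needed for the effect, a lower number that less compound is needed:

compound 1 `O=C(O)CCCO/N=c1/ccn([C@@H]2O[C@H](COP(=O)(O)OP(=O)(O)OP(=O)(O)O)[C@@H](O)[C@H]2O)c(=O)[nH]1` with 299 nM
compound 2 `O=c1[nH]/c(=N\OCCCc2ccc(F)cc2)ccn1[C@@H]1O[C@H](COP(=O)(O)OP(=O)(O)OP(=O)(O)O)[C@@H](O)[C@H]1O` with 547 nM
compound 3 `O=c1[nH]/c(=N\OCCCc2ccncc2)ccn1[C@@H]1O[C@H](COP(=O)(O)OP(=O)(O)OP(=O)(O)O)[C@@H](O)[C@H]1O` with 285 nM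

Compound 3 gives the lowest of the three numbers, yet its neighbours sit close: the step from compound 1 to compound 3 is a 1.0-fold lower number from compound 1 to compound 3 (0.02 log units; within the scatter), and the step from compound 2 to compound 3 is a 1.9-fold lower number from compound 2 to compound 3 (0.28 log units; within the scatter), both within the scatter, so no order among the three can be claimed. Compound 4 `C#CCCCO/N=c1/ccn([C@@H]2O[C@H](COP(=O)(O)OP(=O)(O)OP(=O)(O)O)[C@@H](O)[C@H]2O)c(=O)[nH]1` differs from compound 3 in one place: ethynyl in place of pyridin-4-yl on a saturated chain carbon, three bonds along the chain from an oxygen. The measured steps that bear on this are those at the same place, where the group on that chain carbon was swapped among carboxy, 4-fluorophenyl and pyridin-4-yl: a 1.8-fold higher number from compound 1 to compound 2 (0.26 log units; within the scatter), a 1.0-fold lower number from compound 1 to compound 3 (0.02 log units; within the scatter) and a 1.9-fold lower number from compound 2 to compound 3 (0.28 log units; within the scatter), none of them beyond the scatter. An ethynyl group is not among the groups measured, so the estimate for compound 4 is the step of a 1.2-fold higher number from compound 3 to compound 4 (0.09 log units; within the scatter) in this assay, expected to stay within the scatter, giving for compound 4 an expected 350 nM with a range from 120 nM to 1000 nM.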

Compound 4, half-maximal effective concentration: 168 nM
Compound 4: the middle estimate sits 2.1-fold (0.32 log units) above what was measured, within the range that was stated.
By their numbers in this assay, from the lowest: compounds 4, 3, 1 and 2 (each within the scatter of the next, the first and the last beyond it).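

In this assay, within the data shown here, the ethynyl group, with its 2 heavy atoms and no ring, gives the first step at this chain carbon that lies beyond the scatter, a modest one: a 3.3-fold lower number from compound 2 to compound 4 (0.51 log units; beyond the scatter). Against the other two groups it stays within the scatter, with a 1.7-fold lower number from compound 3 to compound 4 (0.23 log units; within the scatter) and a 1.8-fold lower number from compound 1 to compound 4 (0.25 log units; within the scatter), so at this place ethynyl, pyridin-4-yl and carboxy cannot be put in any order, and only the ethynyl and 4-fluorophenyl compounds stand apart. Nothing measured here accounts for that gap.

The compounds shown leave open what an amine or a hydroxyl group would give on the same chain carbon. They also leave open whether a shorter or longer chain carrying the ethynyl group would keep the number where it stands.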